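Moving the methoxy group around the ring of a chalcone

The source may hold more compounds than are shown below. What is called first, only, known or untested is meant among the compounds shown, and "the series" means these compounds.

Measured compounds:
compound 1, `COc1ccc(/C=C/C(=O)c2ccc(OCCn3cc(CN4C(=O)/C=C/C(C)(C)C/C=C(\C)CC/C=C/4C)nn3)cc2O)cc1`, 1.67 ug/mL
compound 2, `COc1cccc(/C=C/C(=O)c2ccc(OCCn3cc(CN4C(=O)/C=C/C(C)(C)C/C=C(\C)CC/C=C/4C)nn3)cc2O)c1`, 0.61 ug/mL

Compound 2 holds the lower of the two numbers in a functional assay on Lu cells (Homo sapiens) for antiproliferative activity; on this read-out lower numbers stand for stronger inhibition and higher numbers for weaker inhibition; compound 1 sits above it, as the step of a 2.7-fold lower number from compound 1 to compound 2 (0.44 log units; beyond the scatter) shows, which is beyond the scatter.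

Compound 3, `COc1ccccc1/C=C/C(=O)c1ccc(OCCn2cc(CN3C(=O)/C=C/C(C)(C)C/C=C(\C)CC/C=C/3C)nn2)cc1O`, is not yet measured. It differs from compound 2 in one place: 2-methoxyphenyl in place of 3-methoxyphenyl on a double-bonded chain carbon bound to a double-bonded chain carbon.

Among the compounds with values here, only one measured step bears on this change, the step of a 2.7-fold lower number from compound 1 to compound 2 (0.44 log units; beyond the scatter), and it concerns a different pair of ring positions of the same methoxy group, so it says only that shifting this group can move the number by a modest amount. Within the data shown here, no measured pair shows what the 2-methoxyphenyl itself does. The expectation is therefore a small step in this assay, a 1.5-fold higher number from compound 2 to compound 3 (0.17 log units; within the scatter), with a wide range on either side. Compound 3 is estimated at 0.9 ug/mL, between 0.3 ug/mL and 3 ug/mL.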

Compound 3, half-maximal inhibitory concentration: 2.4 ug/mL
Compound 3: the middle estimate sits 2.7-fold (0.43 log units) below what was measured; measured number inside the range.
By their numbers in this assay, from the lowest: compound 2; then compounds 1 and 3 (each within the scatter of the next).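

In this assay, the change of ring position on this double-bonded chain carbon proves not to be a small one: the 2-methoxyphenyl in place of the 3-methoxyphenyl gives a clear loss (a 3.9-fold higher number from compound 2 to compound 3 (0.59 log units; beyond the scatter)), larger in size than the one earlier step among these compounds. Set against the 4-methoxyphenyl, the 2-methoxyphenyl cannot be told apart (a 1.4-fold higher number from compound 1 to compound 3 (0.16 log units; within the scatter)), so among these three compounds the 3-methoxyphenyl of compound 2 alone stands apart, with both of its steps beyond the scatter, while the other two placements read as equal. The data shown offer nothing that accounts for this dependence on ring position.

The compounds shown leave open whether the advantage belongs to the methoxy group itself or to any group in that ring position, as a 3-hydroxyphenyl or a 3-chlorophenyl in the same place would tell. They also leave open whether the same order of the three methoxyphenyl groups would hold with a longer chain linking the triazole-bearing part of the shared core to the rest.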